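Aryl versus saturated amine at the aromatic nitrogen

The source may hold more compounds than are shown below. What is called first, only, known or untested is meant among the compounds shown, and "the series" means these compounds.

Compound 1 `Cc1ccc(CNC(=O)c2cccc(C(C)Oc3ccnc(Nc4cnn(C)c4)c3)c2)cc1` gives 7700 nM in a functional assay on NCI-H3122 cells (Homo sapiens) for antiproliferative activity, read by MTT assay, with a stated time of 48 h; a lower number here means a stronger inhibitor, a higher number a weaker inhibitor. Compound 2 `Cc1ccc(CNC(=O)c2cccc(C(C)Oc3ccnc(NN4CCOCC4)c3)c2)cc1` reaches only the assay limit, > 100000 nM in this assay (the limit of > 100000 nM in this assay, at which 1 of the 3 values shown sits). Compound 3 `Cc1ccc(CNC(=O)c2cccc(C(C)Oc3ccnc(NN4CCCCC4)c3)c2)cc1` gives 37400 nM in this assay, the highest of the two numbers in hand; one step is a 4.9-fold higher number from compound 1 to compound 3 (0.69 log units; beyond the scatter), and against the limit of compound 2 it is an at least 2.6-fold lower number from compound 2 to compound 3 (0.42 log units; beyond the scatter). Compound 4 `COc1cc(Nc2cc(OC(C)c3cccc(C(=O)NCc4ccc(C)cc4)c3)ccn2)cc(OC)c1OC` makes the change (3,4,5-trimethoxyphenyl in place of piperidin-1-yl on a nitrogen on an aromatic ring). Both measured steps at this nitrogen bear on it: the one aromatic substituent seen, in compound 1, gave the lowest number, and the two saturated amine rings gave higher ones. Compound 4 is therefore expected to give a lower number than compound 3 in this assay, a step of about a 9.4-fold lower number from compound 3 to compound 4 (0.97 log units; beyond the scatter), with an estimate of 4000 nM (range 600 nM to 25000 nM).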

Compound 4, half-maximal inhibitory concentration: 7800 nM
The estimate for compound 4 lay 2.0-fold (0.29 log units) below the measured number; the range from low to high includes it.
By their numbers in this assay, from the lowest: compounds 1 and 4 (each within the scatter of the next); then compound 3. At a limit, above all of these: compound 2.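

The 3,4,5-trimethoxyphenyl group and the 1-methyl-1H-pyrazol-4-yl group cannot be told apart on this nitrogen in this assay, with a 1.0-fold higher number from compound 1 to compound 4 (0.01 log units; within the scatter). A second aromatic substituent therefore also gives a lower number than either saturated ring, with a 4.8-fold lower number from compound 3 to compound 4 (0.68 log units; beyond the scatter) and an at least 12-fold lower number from compound 2 to compound 4 (1.10 log units; beyond the scatter). The second of these steps is only a bound, as compound 2 stands at a limit: the limit of > 100000 nM in this assay, at which 1 of the 4 values shown sits.

How much the three methoxy groups contribute remains open, as a plain phenyl is absent from the compounds shown. Also open, as far as these compounds go, is whether an open-chain amine such as dimethylamino would sit with the aromatic groups or the saturated rings.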